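Working notes on a cholesterol transporter binding series

The source may report more compounds than this note shows. Statements on the series, on what has been measured and on what is new or still open speak of the compounds shown alone.

Measured compounds:
compound 1 `COC(=O)CCNC(=O)CN1CN(c2ccccc2)C2(CCN(C(=O)c3ccc(C4CCCCC4)cc3)CC2)C1=O`: 12900 nM
compound 2 `CC(C)(C)OC(=O)NCCCCNC(=O)CN1CN(c2ccccc2)C2(CCN(C(=O)c3ccc(C(C)(C)C)cc3)CC2)C1=O`: "not determined" (no result reported)
compound 3 `COC(=O)CCNC(=O)CN1CN(c2ccccc2)C2(CCN(C(=O)c3ccc(C(C)(C)C)cc3)CC2)C1=O`: "not determined" (no result reported)

In an assay on HEK293 cells for displacement of a labelled ligand from NPC1-like intracellular cholesterol transporter 1 (Homo sapiens) (on this read-out higher numbers stand for weaker inhibition and lower numbers for stronger inhibition), compound 1 gives 12900 nM, a weak result. Compound 2 carries no number in this assay, only "not determined" (no result reported). Compound 3 likewise stands without a number, "not determined" (no result reported), so among the three only compound 1 offers a value to build on.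

Compound 4 `CC1CCCN(C(=O)CN2CN(c3ccccc3)C3(CCN(C(=O)c4ccc(C(C)(C)C)cc4)CC3)C2=O)C1` differs from compound 3 in one place: 3-methylpiperidin-1-yl in place of (2-(methoxycarbonyl)ethyl)amino on a carbonyl carbon. Among the compounds with values here, no measured pair covers this change, so its size cannot be read from the data; in this assay a step in either direction is conceivable, and nothing here supports expecting more than a modest one.

Within the data shown here, compound 4 is expected near 9000 nM, within 2000 nM to 40000 nM, because the sole anchor is compound 1 at 12900 nM.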

Compound 4, half-maximal inhibitory concentration: 12000 nM
Estimate against measurement, compound 4: 1.3-fold (0.12 log units) below, within the range that was stated.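

Within the data shown here, compound 3 has no single number in this assay, and no step to compound 4 can be read. The compounds shown leave open what exchanging (2-(methoxycarbonyl)ethyl)amino for 3-methylpiperidin-1-yl does on this read-out. No evidence bears on this result.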